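The compounds below may be only part of what the source reports. "The series", "measured", "known", "first", "only" and "open" are said of these compounds alone.

Working notes on the acyl dihydropyrazole series.

Of the compounds shown here, two have a number so far. Compound 1 `CCC(=O)N1CCC(C(=O)N2N=CCC2c2ccccc2)CC1` and compound 2 `CC(C)(C)C(=O)N1N=CCC1c1ccc(S(C)(=O)=O)cc1` were both run in a physicochemical assay for lipophilicity, read by HPLC, measured as chromatographic lipophilicity, at pH 7.4; a higher number here means a more lipophilic compound, a lower number a more polar compound. In this assay compound 1 gives 3.2. In this assay compound 2 gives 4.1. Of these two numbers compound 1 stands lowest, and compound 2 lies above it by a gap beyond the scatter. Among the measured compounds shown here, the two differ in more than one place, so this pair shows only that their values differ and supports no single-point step.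

Compound 3 `O=C(c1cc[nH]n1)N1CCC(C(=O)N2N=CCC2c2ccccc2)CC1` has not been measured in this assay. It differs from compound 1 in one place: 1H-pyrazol-3-yl in place of ethyl on a carbonyl carbon. Cut one bond further out, the change reads propanoyl to (1H-pyrazol-3-yl)carbonyl; the ring that enters is a five-membered aromatic ring with two hetero atoms, and it brings one hydrogen-bond donor and one hydrogen-bond acceptor where the ethyl had none.

For the measured compounds named here, no measured step of this kind exists. The step is expected to go downward, beyond the scatter, with an estimated size of a number 0.80 log units lower from compound 1 to compound 3 (beyond the scatter). For compound 3 the expected value in this assay is 2.4, with a range from 1.8 to 3.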

Compound 3, distribution coefficient: 2.4
Estimate against measurement, compound 3: no gap at the digits printed; the measured number falls inside the stated range.
By their numbers in this assay, from the lowest: compound 3; then compound 1; then compound 2.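

The series now holds its first step at a single place: in this assay, 1H-pyrazol-3-yl in place of ethyl on a carbonyl carbon gives a number 0.80 log units lower from compound 1 to compound 3 (beyond the scatter) and stands as a modest change. The number at this position therefore responds beyond the scatter when 2 heavy atoms with no ring give way to 5 heavy atoms in one five-membered aromatic ring with 1 hydrogen-bond donor and 1 hydrogen-bond acceptor, though a single pair sets no trend. This pair cannot separate the contributions of the ring, its hetero atoms and its donor and acceptor, and nothing to hand explains the step.

Open at this carbonyl carbon is how the number would read with a phenyl ring carrying no hetero atoms, with a 1-methylpyrazole that keeps the ring but lacks the ring hydrogen on nitrogen, or with a longer chain in place of ethyl. Also open, as far as these compounds go, is whether the step keeps its size on a compound carrying the methylsulfonyl group of compound 2.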